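Swapping the amide substituent at the cytotoxicity limit

The compounds below may be only part of what the source reports. "The series", "measured", "known", "first", "only" and "open" are said of these compounds alone.

Measured so far in an ADME assay on SH-SY5Y cells (Homo sapiens) for cytotoxicity, read by MTT assay, with a stated time of 48 h; a higher number here means a weaker inhibitor, a lower number a stronger inhibitor:
compound 1 `COc1ccc(C(=O)/C=C/c2ccc(OCCCOc3ccccc3)c(OC)c2)c(O)c1`: > 100000 nM (a limit)
compound 2 `COc1ccc(C(=O)/C=C/c2ccc(C(=O)Nc3ccccc3OC)cc2)c(O)c1`: > 100000 nM (a limit)

Both measured compounds sit at the same limit: the limit of > 100000 nM in this assay, at which 2 of the 2 values shown sit. Compound 2 stands at > 100000 nM, which is a limit of the assay and not a number. Among the measured compounds shown here, no measured step is available, so the size of any change has no direct precedent.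

Compound 3 `COc1ccc(C(=O)/C=C/c2ccc(C(=O)NC(C)C)cc2)c(O)c1` has not yet been measured. It departs from compound 2 through one change, isopropyl in place of 2-methoxyphenyl on an amide-type nitrogen.

The expectation rests on compound 2 , whose > 100000 nM is a limit. Compound 1 , at > 100000 nM, is likewise only a limit. No step beyond the scatter is expected in this assay, in either direction, and the expected change is a number no higher from compound 2 to compound 3 (the limit leaves the size open). A reading at the same limit is the most likely outcome. Compound 3 is estimated at 100000 nM, with an expected range from 40000 nM to 250000 nM.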

Compound 3, half-maximal inhibitory concentration: > 100000 nM
Compound 3 was reported as a limit (the forecaster's own chance of this, stated with the estimate: 75%); the middle value sits exactly at the limit.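

No step can be read between compound 2 and compound 3, because both values are limits and not numbers: the limit of > 100000 nM in this assay, at which 3 of the 3 values shown sit.

The compounds shown leave open whether isopropyl in place of 2-methoxyphenyl on the amide-type nitrogen changes the read-out at all, and where the true half-maximal inhibitory concentration of any of the three lies.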